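A few compounds are considered here, and "the series" means these few. Any claim that something is new, unique, unknown or untested is made for them only; others in the source may bear on it.

Compound 1 `CC(C)Cc1ccc(C(C)C2=NNC(S)N2N)cc1`: 32%
Compound 2 `CC(C)Cc1ccc(C(C)c2nnc(S)n2/N=C/c2ccc(Cl)cc2)cc1`: 49%

Both compounds were tested in a functional assay on the whole organism (strain Wistar albino) for inhibition, with Rattus norvegicus as the target, read by paw edema, with stated times of 30 min and 1 h, at a dose of 20 mg/kg by the oral route; on this read-out lower numbers stand for less inhibition and higher numbers for more inhibition at the one dose given (going by the name of the read-out). Compound 1 gives 32%, and compound 2 gives 49%. Of the two numbers, compound 2 stands highest; its nearest neighbour is compound 1, whose number lies lower by a gap beyond the usual scatter. Among the measured compounds shown here, no two measured compounds differ in just one place, so no single step has been measured.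

Compound 3 `CC(C)Cc1ccc(C(C)c2nnc(S)n2/N=C/c2ccc(Br)cc2)cc1` has not yet been measured. It differs from compound 2 in one place: bromo in place of chloro on an aromatic carbon. Cut one bond further out, the same difference reads 4-chlorophenyl to 4-bromophenyl. For the measured compounds named here, nothing among the measured compounds shows what this exchange does, so no step beyond the scatter in this assay is expected in either direction. The step of a number 1 percentage points higher from compound 2 to compound 3 (within the scatter) is expected to be small. Compound 3 is therefore estimated to give 50%, within a range from 36% to 64%.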

Compound 3, a percentage reported as inhibition, in the whole organism at one dose (the size of the read-out at that dose, not a potency): 16%
The estimate for compound 3 lay 34 percentage points above the measured number; the whole stated range lies above it.
By their numbers in this assay, from the lowest: compound 3; then compound 1; then compound 2.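

In this assay, putting bromo in place of chloro on the aromatic carbon para to a large group gives a number 33 percentage points lower from compound 2 to compound 3 (beyond the scatter), so this position is far from indifferent to which of the two halogens it carries. Chloro and bromo each count as one heavy atom, with no ring, no hydrogen-bond donor or acceptor and no net charge, so an exchange that leaves all these counts unchanged can still move the read-out well beyond the usual scatter. Nothing measured alongside these compounds explains the drop.

A fluoro, methyl or methoxy group at this place, or plain hydrogen, would show whether the loss is peculiar to bromo or whether chloro is the unusual case. This single pair also leaves open whether the same exchange would have a similar effect on a different core.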